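The source may report more compounds than this note shows. Statements on the series, on what has been measured and on what is new or still open speak of the compounds shown alone.

Compound 1 `COC(=O)C(C)(C)NC(=O)c1cc(F)cc2cc(-c3ccc(Cl)cc3)oc12`: "not determined" (no result reported)
Compound 2 `O=C(NC1(C(=O)O)CC1)c1cc(F)cc2cc(-c3ccc(Cl)cc3)oc12`: > 30000 nM

In an assay on isolated protein for inhibition of endoplasmic reticulum aminopeptidase 2 (Homo sapiens) (on this read-out higher numbers stand for weaker inhibition and lower numbers for stronger inhibition), compound 1 carries no result, "not determined" (no result reported). Compound 2 stands at a limit of this assay, not at a number: > 30000 nM. That is the only evidence shown: the limit of > 30000 nM in this assay, at which 1 of the 2 values shown sits.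

Compound 3 `O=C(NC1(C(=O)O)CCCC1)c1cc(F)cc2cc(-c3ccc(Cl)cc3)oc12` differs from compound 2 by 1-carboxycyclopentyl in place of 1-carboxycyclopropyl on an amide-type nitrogen. Among the compounds with values here, no measured step joins compound 2 to any other compound, so no size or direction in this assay is known. The step from compound 2 to compound 3 is expected to be no larger than the scatter, a number no higher from compound 2 to compound 3 (the limit leaves the size open). Compound 3 is expected at 30000 nM, between 10000 nM and 100000 nM.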

Compound 3, half-maximal inhibitory concentration: > 30000 nM
Compound 3 was reported as a limit; the forecaster's own chance of this, stated with the estimate: 70%; the middle value sits exactly at the limit.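

Within the data shown here, compound 2 and compound 3 both stand at a limit of this assay, so no step between them can be read. The compounds shown leave open whether 1-carboxycyclopentyl and 1-carboxycyclopropyl on the amide-type nitrogen differ at all.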